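The source may hold more compounds than are shown below. What is called first, only, known or untested is meant among the compounds shown, and "the series" means these compounds.

Compound 2 `COC(=O)CNC(=O)c1ccc(C#Cc2ccc3c(c2)C=C([N+](=O)[O-])C(C(F)(F)F)O3)cc1` stands at the higher end of the two numbers available in a functional assay on 1321N1 cells for antagonist activity at P2Y purinoceptor 6 (Homo sapiens), read by fluorescence and calcium flux (on this read-out higher numbers stand for weaker inhibition and lower numbers for stronger inhibition), where compound 2 gives 6330 nM. Its nearest neighbour is compound 1 `O=C(O)c1ccc(C#Cc2ccc3c(c2)C=C([N+](=O)[O-])C(C(F)(F)F)O3)cc1`, which in this assay gives 1090 nM; the change from the acid of compound 1 to the glycine ester amide of compound 2 gave a 5.8-fold higher number from compound 1 to compound 2 (0.76 log units; beyond the scatter). Compound 3 `COC(=O)c1ccc(C#Cc2ccc3c(c2)C=C([N+](=O)[O-])C(C(F)(F)F)O3)cc1` is the methyl ester of the same core, and differs from compound 2 by methoxy in place of ((methoxycarbonyl)methyl)amino on a carbonyl carbon. Going by the values given here, no measured step shows the methyl ester directly; the only step that bears on it is the one from compound 1 to compound 2, which ran from the acid to a larger, amide-bearing group and came out modest. Compound 3 sits between the two in the groups it carries, so compound 3 is expected to lie near compound 2 in this assay, the change being estimated as a 1.6-fold lower number from compound 2 to compound 3 (0.20 log units; within the scatter). Compound 3 is therefore estimated at 4000 nM, with a range of 1500 nM to 12000 nM.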

Compound 3, half-maximal inhibitory concentration: 7130 nM
Compound 3: middle estimate off by 1.8-fold (0.25 log units), on the low side, within the range that was stated.
By their numbers in this assay, from the lowest: compound 1; then compounds 2 and 3 (each within the scatter of the next).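

The methyl ester shows that capping the acid needs no larger group: methyl in place of hydrogen on the oxygen alone gives a 6.5-fold higher number from compound 1 to compound 3 (0.82 log units; beyond the scatter) in this assay. Exchanging ((methoxycarbonyl)methyl)amino for methoxy on the carbonyl carbon then gives a 1.1-fold higher number from compound 2 to compound 3 (0.05 log units; within the scatter), so on this read-out the two groups cannot be told apart, and among these three compounds only the acid, compound 1, stands apart from the others. Nothing shown here gives a reason for this outcome.

On these data alone, it remains open whether the free carboxylic acid is itself what sets compound 1 apart, or whether a primary amide on the same carbonyl carbon would stand with it. A glycine amide ending in a free carboxylic acid would also separate the effect of the chain from that of the ester.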